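Trifluoromethyl for fluoro across two aryl series

The source may report more compounds than this note shows. Statements on the series, on what has been measured and on what is new or still open speak of the compounds shown alone.

Compound 1 `O=C(O)CC(NS(=O)(=O)c1ccc(F)cc1)c1ccccc1` gives 88400 nM in a functional assay on MDA-MB-231 cells (Homo sapiens) for antiproliferative activity, read by MTT assay, with a stated time of 24 h; on this read-out higher numbers stand for weaker inhibition and lower numbers for stronger inhibition. Compound 2 `O=C(O)CC(NS(=O)(=O)c1ccc(C(F)(F)F)cc1)c1ccccc1` gives 56100 nM in this assay. The change between them is trifluoromethyl in place of fluoro on an aromatic carbon, and the resulting step is a 1.6-fold lower number from compound 1 to compound 2 (0.20 log units; within the scatter).

Compound 3 `O=C(O)CC(NC(=O)c1ccc(F)cc1)c1ccccc1F` carries a different core; the difference between its core and that of compound 1 is not broken down here. In this assay compound 3 gives 72300 nM, which lies within the scatter of the values of both compound 1 and compound 2, so no ordering among the three is claimed.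

Compound 4 `O=C(O)CC(NC(=O)c1ccc(C(F)(F)F)cc1)c1ccccc1F` is still to be measured. It differs from compound 3 by trifluoromethyl in place of fluoro on an aromatic carbon, the same change that led from compound 1 to compound 2. On the core of compound 1 that change produced a 1.6-fold lower number from compound 1 to compound 2 (0.20 log units; within the scatter), a step within the scatter. Going by the values given here, compound 4 is therefore expected to show a similar small step, a 1.5-fold lower number from compound 3 to compound 4 (0.18 log units; within the scatter), because of a 1.6-fold lower number from compound 1 to compound 2 (0.20 log units; within the scatter) and the single precedent it provides. Compound 4 is estimated at 48000 nM in this assay, with a likely range from 24000 nM to 100000 nM.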

Compound 4, half-maximal inhibitory concentration: 59200 nM
Compound 4: middle estimate off by 1.2-fold (0.09 log units), on the low side, within the range that was stated.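

In this assay, trifluoromethyl in place of fluoro on the second core gives a 1.2-fold lower number from compound 3 to compound 4 (0.09 log units; within the scatter), and set beside the step on the core of compound 1, the two steps do not separate: the same change on two cores in this assay, a 1.6-fold lower number (0.20 log units; within the scatter) from compound 1 to compound 2 and a 1.2-fold lower number (0.09 log units; within the scatter) from compound 3 to compound 4, 1.3-fold (0.11 log units) apart, within the scatter of two such steps. The change therefore behaves alike on these two cores, with a small step on each and no sign that the core alters its size. It does not show a real gain in inhibition on either core, as both steps lie within the scatter, and two cores give no basis for a rule across the whole series.

Open, on these data alone, is whether any other group on that aromatic carbon, such as an amine, a carboxylic acid or a longer alkyl chain, would move the number beyond the scatter. Also open, as far as these compounds go, is how the change would behave on a core other than these two, and which of the differences between the two cores bears on the values.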